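From chloro to thiophenyl at the same aromatic carbon

The source may report more compounds than this note shows. Statements on the series, on what has been measured and on what is new or still open speak of the compounds shown alone.

Measured so far:
compound 1 `CN1CCCN(CCn2ccc3ccc(Cl)cc32)CC1`: 34 nM
compound 2 `CCc1ccc2ccn(CCN3CCCN(C)CC3)c2c1`: 166 nM

In an assay on HEK293 cells for binding affinity to 5-hydroxytryptamine receptor 7 (Homo sapiens), read by radioligand binding (on this read-out lower numbers stand for stronger inhibition and higher numbers for weaker inhibition), compound 1 gives the lower of the two numbers shown. Within the data shown here, the only neighbouring number comes from compound 2, and that step, a 4.9-fold higher number from compound 1 to compound 2 (0.69 log units; beyond the scatter), involves a chloro giving way to a small chain at the same aromatic carbon. Compound 3 `CN1CCCN(CCn2ccc3ccc(-c4ccsc4)cc32)CC1` is not yet measured; it differs from compound 1 in one place: thiophen-3-yl in place of chloro on an aromatic carbon. Among the measured compounds shown here, the step from compound 1 to compound 2 is the only comparison that bears on this change, and it was modest. For the measured compounds named here, a thiophen-3-yl is a different kind of group from ethyl, so the step to compound 3 is uncertain, but the one known change away from chloro weakened binding. Compound 3 is therefore expected to be somewhat weaker than compound 1, a step of a 2.4-fold higher number from compound 1 to compound 3 (0.37 log units; beyond the scatter), with a wide range. The estimate for compound 3 in this assay is 80 nM, between 20 nM and 320 nM.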

Compound 3, inhibition constant: 109 nM
Beside the measured number, compound 3's estimate is 1.4-fold (0.13 log units) below it, within the range that was stated.
By their numbers in this assay, from the lowest: compound 1; then compounds 3 and 2 (each within the scatter of the next).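

In this assay, a second replacement of chloro also gives a higher number (a 3.2-fold higher number from compound 1 to compound 3 (0.51 log units; beyond the scatter)), so chloro holds the lowest number against both a small chain and a five-membered aromatic ring. The two replacements cannot be told apart (a 1.5-fold lower number from compound 2 to compound 3 (0.18 log units; within the scatter)), even though thiophen-3-yl brings a ring, a sulfur atom and a hydrogen-bond acceptor that ethyl does not have. Nothing shown here gives a reason for these steps.

Still open, as far as these compounds go, is whether another halogen, such as fluoro or bromo, would match chloro at this carbon, or whether chloro stands apart. Also open, from the compounds shown here alone, is how a methoxy, an amine or a phenyl ring would fare here, and whether thiophen-2-yl would differ from thiophen-3-yl.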